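The source may hold more compounds than are shown below. What is called first, only, known or untested is meant among the compounds shown, and "the series" means these compounds.

Of the compounds shown here, two have so far been measured in an assay on cells for inhibition of MAP kinase-interacting serine/threonine-protein kinase 1 (Homo sapiens), read by mobility shift assay, with stated times of 10 min and 60 min, in the presence of a further agent that is not named here; a lower number here means a stronger inhibitor, a higher number a weaker inhibitor. Compound 1 `Cc1n[nH]c(C)c1-c1cncc(-c2ccc(C(N)=O)c(OC(C)C)c2)c1` gives 33 nM in this assay, the lowest of the two numbers. Compound 2 `Nc1snnc1-c1ccc(C(F)(F)F)cc1` gives 50000 nM in this assay; it is built on a different core, and the gap from compound 1 to compound 2 is beyond the scatter. Compound 1 is therefore the anchor for the next step.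

Compound 3 `CC(C)Oc1cc(-c2cncc(-c3cnn(C4COC4)c3)c2)ccc1C(N)=O` has not yet been measured. It differs from compound 1 in one place: 1-(oxetan-3-yl)-1H-pyrazol-4-yl in place of 3,5-dimethyl-1H-pyrazol-4-yl on an aromatic carbon. The shared core, the amide and the isopropoxy group are untouched. Within the data shown here, no pair of measured compounds differs only at this spot, so nothing is known about how the potency responds to a change here, and the size of the step is uncertain.

A modest loss is expected, with the step of a 2.4-fold higher number from compound 1 to compound 3 (0.38 log units; beyond the scatter) expected to lie near the edge of the scatter rather than far beyond it. Compound 3 is accordingly estimated at 80 nM in this assay, within a range from 20 nM to 400 nM.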

Compound 3, half-maximal inhibitory concentration in the MAP kinase-interacting serine/threonine-protein kinase 1 assay: 200 nM
Estimate against measurement, compound 3: 2.5-fold (0.40 log units) below; low and high end bracket the measured number.
By their numbers in the MAP kinase-interacting serine/threonine-protein kinase 1 assay, from the lowest: compound 1; then compound 3; then compound 2.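

In the MAP kinase-interacting serine/threonine-protein kinase 1 assay, this position proves sensitive to the change, which gives a 6.1-fold higher number from compound 1 to compound 3 (0.78 log units; beyond the scatter), so 1-(oxetan-3-yl)-1H-pyrazol-4-yl is tolerated but is a clear step down from 3,5-dimethyl-1H-pyrazol-4-yl. The same change moves a second property in a favourable direction: in a physicochemical assay for solubility, measured as thermodynamic solubility, at pH 7.4 (a higher number here means a more soluble compound, a lower number a less soluble compound), compound 1 gives 10 ug/mL and compound 3 gives 28 ug/mL. This pair therefore shows a trade rather than a plain loss, with potency given up and solubility gained at a single position on a shared core: the measured solubility of compound 1, 10 ug/mL, and of compound 3, 28 ug/mL, a 2.8-fold higher number (0.45 log units; beyond the scatter)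

One pair cannot separate the parts of this change, since the entering group has 0 hydrogen-bond donors where the leaving group has 1, and it also brings a four-membered non-aromatic ring. Going by these compounds, whether a methyl group or an amine in place of the oxetan-3-yl group would keep more of the potency of compound 1 while retaining the solubility of compound 3 remains open.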